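A trifluoromethyl replacement on compound 3

This account rests on a few compounds, and the source may have more. Where it says the series, first, only, none or still open, it means among the compounds named here.

Compound 1 `CS(=O)(=O)NC(=O)CCc1cn(-c2cccc(Br)c2)nc1-c1ccc(Cl)cc1` gives < 5000 nM (a limit of the assay)
Compound 2 `CS(=O)(=O)NC(=O)CCc1cn(-c2ccc(Cl)cc2)nc1-c1ccc(Cl)cc1` gives 100000 nM
Compound 3 `CS(=O)(=O)NC(=O)CCc1cn(-c2ccc(C(F)(F)F)cc2)nc1-c1ccc(Cl)cc1` gives 50000 nM

In a physicochemical assay for solubility, in phosphate buffer, measured as thermodynamic solubility, at pH 7.4 (on this read-out lower numbers stand for lower solubility and higher numbers for higher solubility), compound 3 stands at 50000 nM and cannot be separated from its nearest neighbour, as the data show a 2.0-fold lower number from compound 2 to compound 3 (0.30 log units; within the scatter). Compound 1 gives only a limit (< 5000 nM). The steps away from it are an at least 20-fold higher number from compound 1 to compound 2 (1.30 log units; beyond the scatter) and an at least 10-fold higher number from compound 1 to compound 3 (1.00 log units; beyond the scatter), but both replace a different group.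

Compound 4 `C[S+]([O-])c1ccc(-n2cc(CCC(=O)NS(C)(=O)=O)c(-c3ccc(Cl)cc3)n2)cc1` differs from compound 3 at one place: a group of 3 heavy atoms (1 carbon, 1 oxygen, 1 sulfur; no ring) in place of a group of 4 heavy atoms (1 carbon, 3 fluorine; no ring), on an aromatic carbon. The change sits on an aromatic carbon, para to a large group. The closest measured precedent is the exchange at that same place, a 2.0-fold lower number from compound 2 to compound 3 (0.30 log units; within the scatter), which stayed small. Within the data shown here, no measured step involves the entering group, so the expectation is uncertain. With one hydrogen-bond acceptor entering where none leaves, a moderate move towards a higher number is expected in this assay. The estimated step is a 3.0-fold higher number from compound 3 to compound 4 (0.48 log units; beyond the scatter). For compound 4 the expected value is 150000 nM, with an estimated range from 40000 nM to 500000 nM.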

Compound 4, solubility: 200000 nM
The estimate for compound 4 lay 1.3-fold (0.12 log units) below the measured number; measured number inside the range.
By their numbers in this assay, from the lowest: compounds 3, 2 and 4 (each within the scatter of the next, the first and the last beyond it). At a limit, below all of these: compound 1.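

At this place, on an aromatic carbon para to a large group, the group of 3 heavy atoms (1 carbon, 1 oxygen, 1 sulfur) in place of trifluoromethyl gives a 4.0-fold higher number from compound 3 to compound 4 (0.60 log units; beyond the scatter) in this assay, so a change here can move the number beyond the scatter, which the exchange of chloro for trifluoromethyl, a 2.0-fold lower number from compound 2 to compound 3 (0.30 log units; within the scatter), did not do. Set against chloro, the same group gives a 2.0-fold higher number from compound 2 to compound 4 (0.30 log units; within the scatter), so compound 4 cannot be separated from compound 2. Compound 1 gives only a limit, and an at least 40-fold higher number from compound 1 to compound 4 (1.60 log units; beyond the scatter) rests on that limit, which also involves a change of the substituted phenyl group: the limit of < 5000 nM in this assay, at which 1 of the 4 values shown sits.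

The compounds shown leave open how an amine, a carboxylic acid or a longer chain at this place would read in this assay. They also leave open whether the step from trifluoromethyl would hold with another group in place of the 4-chlorophenyl on the shared core.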